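Fluoro on the aniline ring of a benzothiazolyl thiourea series

A few compounds are considered here, and "the series" means these few. Any claim that something is new, unique, unknown or untested is made for them only; others in the source may bear on it.

compound 1 `Fc1ccc(NC(=S)Nc2nc3ccccc3s2)cc1`: 26700 nM
compound 2 `Fc1ccc(NC(=S)Nc2nc3ccc(F)cc3s2)cc1`: 34600 nM
compound 3 `Cc1ccc2nc(NC(=S)Nc3ccccc3)sc2c1`: > 50000 nM, a limit of the assay, not a number

In a functional assay on THP-1 cells (Homo sapiens) for cytotoxicity, read by MTT assay, with a stated time of 48 h (a higher number here means a weaker inhibitor, a lower number a stronger inhibitor), compound 3 sits at the limit of > 50000 nM in this assay, at which 1 of the 3 values shown sits; only the limit is known, no number. Compound 4 `Cc1ccc2nc(NC(=S)Nc3ccc(F)cc3)sc2c1` differs from compound 3 by fluoro in place of hydrogen on an aromatic carbon. Among the measured compounds shown here, the one measured step of the same kind, a 1.3-fold higher number from compound 1 to compound 2 (0.11 log units; within the scatter), places the fluoro on the other ring of the shared core, so no measured step matches the place of this change. Any effect of fluoro seen so far is within the scatter. The expected step is a step that the limit leaves unreadable from compound 3 to compound 4, nothing beyond the scatter. Compound 4 is therefore expected to give 60000 nM, with a range of 30000 nM to 150000 nM, and most likely to be reported again only as a limit.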

Compound 4, half-maximal inhibitory concentration: 36900 nM
Compound 4: the middle estimate sits 1.6-fold (0.21 log units) above what was measured, within the range that was stated.
By their numbers in this assay, from the lowest: compounds 1, 2 and 4 (each within the scatter of the next). At a limit, above all of these: compound 3.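

In this assay, phenyl to 4-fluorophenyl at this place gives a number where the unfluorinated partner gives only a limit, and an at least 1.3-fold lower number from compound 3 to compound 4 (0.13 log units; that floor lies within the scatter) fixes a floor for the step, not its size. With 4-fluorophenyl held, the substituent on the other ring of the shared core changes nothing beyond the scatter, with a 1.1-fold higher number from compound 2 to compound 4 (0.03 log units; within the scatter) and a 1.4-fold higher number from compound 1 to compound 4 (0.14 log units; within the scatter). The comparison of this change across two cores stays open: the same change on two cores in this assay, a 1.3-fold higher number (0.11 log units; within the scatter) from compound 1 to compound 2 and an at least 1.3-fold lower number (0.13 log units; that floor lies within the scatter) from compound 3 to compound 4; the limit leaves it open whether they differ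

Going by these compounds, whether an amine or a carboxylic acid in place of the fluoro would move the number beyond the scatter remains open.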